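The source may hold more compounds than are shown below. What is called first, only, known or untested is meant among the compounds shown, and "the series" means these compounds.

Measured in a functional assay on A549 cells (Homo sapiens) for antiproliferative activity, read by MTT assay, with a stated time of 72 h; a higher number here means a weaker inhibitor, a lower number a stronger inhibitor:
compound 1 `Nc1nc(N)c2cc(CSC(=S)N3CCN(c4ccc(O)cc4)CC3)ccc2n1`: 4210 nM
compound 2 `Cc1ccc(N2CCN(C(=S)SCc3ccc4nc(N)nc(N)c4c3)CC2)cc1`: 2190 nM
compound 3 `Nc1nc(N)c2cc(CSC(=S)N3CCN(c4ccccc4Cl)CC3)ccc2n1`: 3610 nM

Compound 3, at 3610 nM, does not separate from the other two compounds. Its steps are a 1.2-fold lower number from compound 1 to compound 3 (0.07 log units; within the scatter) and a 1.6-fold higher number from compound 2 to compound 3 (0.22 log units; within the scatter).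

The next compound, compound 4 `Nc1nc(N)c2cc(CSC(=S)N3CCN(c4ccc(Cl)c(Cl)c4)CC3)ccc2n1`, keeps the shared core and has 3,4-dichlorophenyl in place of 2-chlorophenyl on an amine nitrogen in a ring.

Within the data shown here, three measured steps bear on this change, since all of them alter the aromatic group at that same place. Besides the two steps above, there is a 1.9-fold lower number from compound 1 to compound 2 (0.28 log units; within the scatter). All three stay within the scatter, so the aromatic groups tried so far have not moved the number measurably. None of these compounds carries the 3,4-dichlorophenyl group, however, so the data do not test that group directly, and the range must stay wider than the spread seen so far.

No step beyond the scatter is therefore expected in this assay, and no direction can be favoured. The expected change is a 1.2-fold lower number from compound 3 to compound 4 (0.08 log units; within the scatter). The estimate for compound 4 is 3000 nM, with an expected range of 1300 nM to 6500 nM.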

Compound 4, half-maximal inhibitory concentration: 2940 nM
Compound 4: middle estimate off by 1.0-fold (0.01 log units), on the high side; the range from low to high includes it.
By their numbers in this assay, from the lowest: compounds 2, 4, 3 and 1 (each within the scatter of the next).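

In this assay the 3,4-dichlorophenyl group on the amine nitrogen in the ring does not separate from any of the three earlier aromatic groups: there is a 1.2-fold lower number from compound 3 to compound 4 (0.09 log units; within the scatter) and a 1.3-fold higher number from compound 2 to compound 4 (0.13 log units; within the scatter) and a 1.4-fold lower number from compound 1 to compound 4 (0.16 log units; within the scatter). The 4-hydroxyphenyl, 4-methylphenyl, 2-chlorophenyl and 3,4-dichlorophenyl compounds therefore form one flat set at this place, and going from one chlorine to two on the ring, with the chlorine positions changed as well, gives no measurable shift. No accompanying measurement offers an explanation for this flatness.

Open, on these data alone, is whether a carboxylic acid or an amine on that aromatic ring, or a benzyl group or a short alkyl chain in place of the ring, would give a step beyond the scatter. Also open, as far as these compounds go, is whether the number responds to any change outside this place, as all four compounds keep the rest of the structure unchanged.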